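The compounds below may be only part of what the source reports. "The series", "measured", "known", "first", "only" and "open" are said of these compounds alone.

Going by the values given here, in a functional assay on MCF7 cells (Homo sapiens) for antiproliferative activity, read by MTT assay, with a stated time of 72 h (a lower number here means a stronger inhibitor, a higher number a weaker inhibitor), compound 1 `Cc1cccc(CSc2cc(Cl)c(C)cc2S(=O)(=O)/N=C(\N)N/N=C/C#Cc2ccccc2)c1` gives 16000 nM, the lowest number among the three compounds measured so far. Compound 2 `C/C(C#Cc1ccccc1)=N\N/C(N)=N/S(=O)(=O)c1cc(C)c(Cl)cc1SCc1cccc(C)c1` gives 130000 nM, and compound 3 `C/C(C#Cc1ccccc1)=N\N/C(N)=N/S(=O)(=O)c1cc(C)c(Cl)cc1SCc1ccc(C)cc1` gives 125000 nM. The step that changes the group on the amine nitrogen reads an 8.1-fold higher number from compound 1 to compound 2 (0.91 log units; beyond the scatter). Among the compounds with values here, the one step that touches only the aryl group on the saturated chain carbon bound to a sulfur reads a 1.0-fold lower number from compound 2 to compound 3 (0.02 log units; within the scatter).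

Compound 4 `Cc1cc(S(=O)(=O)/N=C(\N)N/N=C/C#Cc2ccccc2)c(SCc2cccc3ccccc23)cc1Cl` has not yet been measured in this assay. It differs from compound 1 in a single place: naphthalen-1-yl in place of 3-methylphenyl on a saturated chain carbon bound to a sulfur. The step between compound 2 and compound 3 is the only measured one that bears on this position, and it stayed within the scatter. Within the data shown here, no measured step puts a naphthalen-1-yl group in this place, so the larger group reaches beyond what the three numbers cover, and the expectation rests on a single comparison. On that basis the step to compound 4 is expected to read no change at the digits printed from compound 1 to compound 4 (within the scatter), not beyond the scatter, with the uncertainty widened for the untested group. The estimate for compound 4 in this assay is 16000 nM, with a range from 5000 nM to 50000 nM.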

Compound 4, half-maximal inhibitory concentration: 22000 nM
Compound 4: the middle estimate sits 1.4-fold (0.14 log units) below what was measured; the range from low to high includes it.
By their numbers in this assay, from the lowest: compounds 1 and 4 (each within the scatter of the next); then compounds 3 and 2 (each within the scatter of the next).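

In this assay, going by these compounds alone, the replacement of 3-methylphenyl by naphthalen-1-yl on a saturated chain carbon bound to a sulfur reads a 1.4-fold higher number from compound 1 to compound 4 (0.14 log units; within the scatter), so at this place a second six-membered aromatic ring leaves the number within the scatter of the one for compound 1. The earlier comparison at this position, a 1.0-fold lower number from compound 2 to compound 3 (0.02 log units; within the scatter), only moved a methyl group around a single phenyl ring and belonged to the pair carrying the other group on the amine nitrogen; the new step extends the flat reading at this place to a much larger change in the group, and to the compound 1 side of that amine nitrogen change. Nothing at hand offers an explanation for this reading.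

The compounds shown leave open whether naphthalen-1-yl would read the same alongside the amine nitrogen group of compound 2 and compound 3. They also leave open whether this place would stay as flat with a carboxylic acid or an amine on the ring, with naphthalen-2-yl, or with a longer chain between the sulfur and the ring.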